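Compound 4: a further sulfur substituent at the limit?

The source may hold more compounds than are shown below. What is called first, only, known or untested is meant among the compounds shown, and "the series" means these compounds.

Measured in a functional assay on DU-145 cells (Homo sapiens) for inhibition, read by trypan blue exclusion, with a stated time of 96 h; a higher number here means a weaker inhibitor of growth, a lower number a stronger inhibitor of growth:
- compound 1 `CN(C)c1ccc(/C=C(/SCc2ccccc2Cl)C(=O)c2ccc(Cl)cc2)cc1` gives the limit > 100000 nM
- compound 2 `CN(C)c1ccc(/C=C(\C(=O)c2ccc(Cl)cc2)S(=O)(=O)c2ccc(Br)cc2)cc1` gives the limit > 100000 nM
- compound 3 `CN(C)c1ccc(/C=C(/Sc2ccc(Br)cc2)C(=O)c2ccc(Cl)cc2)cc1` gives the limit > 100000 nM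

Compound 3 stands at > 100000 nM, a limit and not a number. The whole series sits at the limit of > 100000 nM in this assay, at which 3 of the 3 values shown sit.

Compound 4 `CN(C)c1ccc(/C=C(/SCc2ccc(Cl)c(Cl)c2)C(=O)c2ccc(Cl)cc2)cc1` differs from compound 3 by 3,4-dichlorobenzyl in place of 4-bromophenyl on a sulfur, with 3,4-dichlorobenzyl in place of 4-bromophenyl on a sulfur. The closest measured change is a step that the two limits leave unreadable from compound 1 to compound 3, and a step that the two limits leave unreadable from compound 2 to compound 3 concerns the same sulfur. Neither gives a size to carry over, so no step beyond the scatter and no direction can be expected in this assay. The expected step is a number no higher from compound 3 to compound 4 (the limit leaves the size open). Compound 4 is estimated at 100000 nM, with an expected range of 30000 nM to 300000 nM.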

Compound 4, concentration for 50% growth inhibition: 50000 nM
For compound 4 the middle estimate is 2.0-fold (0.30 log units) above the measured one; measured number inside the range.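

On the sulfur, 3,4-dichlorobenzyl gives the only value in this assay that is a number, while the other compounds stay at a limit: the limit of > 100000 nM in this assay, at which 3 of the 4 values shown sit.

In place of 4-bromophenyl on that sulfur it gives an at least 2.0-fold lower number from compound 3 to compound 4 (0.30 log units; that floor lies within the scatter), the (3,4-dichlorobenzyl)sulfanyl for (4-bromophenyl)sulfonyl change gives an at least 2.0-fold lower number from compound 2 to compound 4 (0.30 log units; that floor lies within the scatter), and 3,4-dichlorophenyl for 2-chlorophenyl on the saturated chain carbon gives an at least 2.0-fold lower number from compound 1 to compound 4 (0.30 log units; that floor lies within the scatter). Each of these is only a floor, and the steps among compound 1, compound 2 and compound 3 cannot be read.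

From the compounds shown here alone, what a longer chain or a carboxylic acid in place of 3,4-dichlorobenzyl on the sulfur would give in this assay stays open.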